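A few compounds are considered here, and "the series" means these few. Any claim that something is new, unique, unknown or untested is made for them only; others in the source may bear on it.

Compound 1 `CC1(C)[C@H]2CC[C@]1(C)N(Cc1cn(-c3cccc(Cl)c3)nn1)C(=O)C2`: 70 nM.
Compound 2 `CC1(C)[C@H]2CC[C@]1(C)N(Cc1cn(-c3ccc(Cl)cc3)nn1)C(=O)C2`: 160 nM.
Compound 3 `CC1(C)[C@H]2CC[C@]1(C)N(Cc1cn(-c3cccc(Br)c3)nn1)C(=O)C2`: 30 nM.

In a functional assay on LoVo cells (Homo sapiens) for inhibition, read by MTT assay, with a stated time of 24 h (on this read-out lower numbers stand for stronger inhibition and higher numbers for weaker inhibition), compound 3 gives the lowest of the three numbers. The nearest gap is a 2.3-fold lower number from compound 1 to compound 3 (0.37 log units; beyond the scatter); the furthest is a 5.3-fold lower number from compound 2 to compound 3 (0.73 log units; beyond the scatter). Compound 4 `CC1(C)[C@H]2CC[C@]1(C)N(Cc1cn(-c3ccc(Br)cc3)nn1)C(=O)C2` differs from compound 3 by 4-bromophenyl in place of 3-bromophenyl on an aromatic nitrogen. Among the compounds with values here, one measured step bears on this change: a 2.3-fold higher number from compound 1 to compound 2 (0.36 log units; beyond the scatter), where the same shift of the halogen on the phenyl was made with chloro. A step of similar size and direction, a modestly higher number beyond the scatter, is therefore expected in this assay. Compound 4 is estimated to give 70 nM, with a range from 35 nM to 150 nM. The expected step is a 2.3-fold higher number from compound 3 to compound 4 (0.37 log units; beyond the scatter).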

Compound 4, half-maximal inhibitory concentration: 60 nM
Compound 4: the middle estimate sits 1.2-fold (0.07 log units) above what was measured; the range from low to high includes it.
By their numbers in this assay, from the lowest: compounds 3, 4 and 1 (each within the scatter of the next, the first and the last beyond it); then compound 2.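

In this assay, 4-bromophenyl in place of 3-bromophenyl gives a 2.0-fold higher number from compound 3 to compound 4 (0.30 log units; within the scatter), so with bromo this shift stays within the scatter, unlike the same shift with chloro. With the halogen placed as in compound 4, bromo in place of chloro gives a 2.7-fold lower number from compound 2 to compound 4 (0.43 log units; beyond the scatter), while the comparison with the 3-chlorophenyl compound gives a 1.2-fold lower number from compound 1 to compound 4 (0.07 log units; within the scatter). The change from chloro to bromo thus reads alike for both halogen placements: the same change on two cores in this assay, a 2.3-fold lower number (0.37 log units; beyond the scatter) from compound 1 to compound 3 and a 2.7-fold lower number (0.43 log units; beyond the scatter) from compound 2 to compound 4, 1.1-fold (0.06 log units) apart, within the scatter of two such steps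

The compounds shown leave open how iodo, methoxy or an amine on this phenyl would read, and whether the unsubstituted phenyl would fall with them.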